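Working notes: methoxy on the phenyl of compound 2

This account rests on a few compounds, and the source may have more. Where it says the series, first, only, none or still open, it means among the compounds named here.

- compound 1 `COc1ccc(-c2cnc(NC(C)=O)n2C)cc1` gives > 100000 nM
- compound 2 `Cn1c(-c2ccccc2)cnc1NC(=O)c1cccc(Br)c1` gives > 50000 nM

In a toxicity assay on THP-1 cells (Homo sapiens) for inhibition (a lower number here means that less compound is tolerated, a higher number that more compound is tolerated), compound 2 stands at > 50000 nM and this value is a limit of the assay. Among the compounds with values here, neither measured compound has a numeric value, so no measured step is available. Compound 3 `COc1ccc(-c2cnc(NC(=O)c3cccc(Br)c3)n2C)cc1` differs from compound 2 by methoxy in place of hydrogen on an aromatic carbon and the same difference reads phenyl to 4-methoxyphenyl. A step beyond the scatter in this assay is not expected in either direction, since compound 1 with the same 4-methoxyphenyl group gives > 100000 nM as a limit. The expected step that the limit leaves unreadable from compound 2 to compound 3 is no larger than the scatter. For compound 3 the estimated value is 70000 nM with an expected range from 30000 nM to 150000 nM and a report as a limit alone is likely.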

Compound 3, half-maximal cytotoxic concentration: > 100000 nM
Compound 3: only a limit was reported (the forecaster's own chance of this, stated with the estimate: 75%); at least 1.4-fold (0.15 log units) between middle value and limit.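

No new step can be read: the comparisons of compound 2 with compound 3 and of compound 1 with compound 3 rest only on limits of the assay. The compounds shown leave open what size either change has in this assay when values lie within the measurable range.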